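The compounds below may be only part of what the source reports. "The series", "measured", "known", "first", "only" and "open" are said of these compounds alone.

Measured so far in a functional assay on CCRF-CEM/VCR-1000 cells (Homo sapiens) for inhibition; on this read-out higher numbers stand for weaker inhibition and lower numbers for stronger inhibition:
compound 1 `CC(C)N(CC(O)COc1ccc(O)cc1C(=O)CCc1ccccc1)C(C)C`: 1040 nM
compound 2 `OC(COc1ccccc1C(O)CCc1ccccc1)CN1CCN(c2ccc(F)cc2)CC1`: 670 nM
compound 3 `CC(C)N(CC(O)COc1ccccc1C(=O)CCc1ccccc1)C(C)C`: 310 nM

Compound 1 has the highest of the three numbers; its gap to compound 2 is within the scatter, while the step of a 3.4-fold lower number from compound 1 to compound 3 (0.53 log units; beyond the scatter) lies beyond it. Compound 4 `O=C(CCc1ccccc1)c1cc(O)ccc1OCC(O)CN1CCCCC1` arises from compound 1 by piperidin-1-yl in place of diisopropylamino on a saturated chain carbon, two bonds along the chain from an oxygen on a saturated carbon. For the measured compounds named here, the only step measured in this assay concerns the ring hydroxy and so does not bear on the amine exchange; compound 2 carries a different cyclic amine but also differs elsewhere, so only its value can be set beside that of compound 1. Going by the values given here, with no directly comparable step, no change beyond the scatter is expected in this assay: the estimated step is a 1.2-fold lower number from compound 1 to compound 4 (0.06 log units; within the scatter). Compound 4 is therefore estimated at 900 nM, with a range from 350 nM to 2500 nM.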

Compound 4, half-maximal inhibitory concentration: 2300 nM
Estimate against measurement, compound 4: 2.6-fold (0.41 log units) below, and the stated range covers the measured number.
By their numbers in this assay, from the lowest: compound 3; then compounds 2 and 1 (each within the scatter of the next); then compound 4.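

In this assay, for the compounds shown here, this place on the chain is not indifferent to the amine: exchanging diisopropylamino for piperidin-1-yl gives a 2.2-fold higher number from compound 1 to compound 4 (0.34 log units; beyond the scatter) as the first measured step here. On the core of compound 1, the open-chain amine therefore holds the lower number, though this reading rests on a single pair. Nothing on hand accounts for the step.

As far as these compounds go, whether the same exchange gives a similar step on the core of compound 3, without the ring hydroxy, stays open. So does the response to other amines, such as pyrrolidin-1-yl or morpholin-4-yl, at this place.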